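A Halogen Swap on the Amide Ring: Estimating Compound 4

The compounds below may be only part of what the source reports. "The series", "measured", "known", "first", "only" and "open" are said of these compounds alone.

Of the compounds shown here, three sharing one core have been tested in a functional assay on Raji cells (Homo sapiens) for antiproliferative activity, read by CCK-8 assay, with a stated time of 72 h, tested at 40 uM; on this read-out higher numbers stand for more inhibition at the one concentration tested (going by the name of the read-out) and lower numbers for less inhibition. Compound 1 `CCOC(=O)c1sc(-c2cccc(NC(=O)c3ccc(F)c(Cl)c3)c2)nc1Nc1ccc(N2CCN(C)CC2)cc1` gives 20.7%. Compound 2 `CN1CCN(c2ccc(Nc3nc(-c4cccc(NC(=O)c5ccccc5)c4)sc3C(=O)O)cc2)CC1` gives 11.9%. Compound 3 `CN1CCN(c2ccc(Nc3nc(-c4cccc(NC(=O)c5ccccc5F)c4)sc3C(=O)O)cc2)CC1` gives 86.9%, the highest of the three, and its distance to both compound 1 and compound 2 lies beyond the usual scatter.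

Among the measured compounds shown here, the only single-point step among the measured compounds is a number 75 percentage points higher from compound 2 to compound 3 (beyond the scatter). It shows that a single fluorine on this ring can move the read-out strongly, but says nothing directly about a different halogen pattern.

Compound 4 `CN1CCN(c2ccc(Nc3nc(-c4cccc(NC(=O)c5ccc(F)c(Cl)c5)c4)sc3C(=O)O)cc2)CC1` differs from compound 3 in one place: 3-chloro-4-fluorophenyl in place of 2-fluorophenyl on a carbonyl carbon. For the measured compounds named here, no measured pair isolates this change. Compound 1 carries the same 3-chloro-4-fluorophenyl group as compound 4 but with an ester instead of the acid, and its number was low, so it only hints that this ring does not by itself secure a high result. Against that stands the large gain with 2-fluorophenyl in compound 3. Weighing both, the step of a number 51.9 percentage points lower from compound 3 to compound 4 (beyond the scatter) is expected to be a clear drop. The value for compound 4 is estimated at 35%, within a range from 10% to 80%.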

Compound 4, a percentage reported as inhibition, at one concentration (the size of the read-out at that concentration, not a potency): 87.9%
For compound 4 the middle estimate is 52.9 percentage points below the measured one; the whole stated range lies below it.
By their numbers in this assay, from the lowest: compounds 2 and 1 (each within the scatter of the next); then compounds 3 and 4 (each within the scatter of the next).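

In this assay, the step of a number 1 percentage points higher from compound 3 to compound 4 (within the scatter) means that 3-chloro-4-fluorophenyl and 2-fluorophenyl on this carbonyl carbon cannot be told apart, and the step of a number 76 percentage points higher from compound 2 to compound 4 (beyond the scatter) shows that the gain over plain phenyl is not tied to the 2-fluorophenyl group alone. The ring of compound 1 is therefore compatible with a high number once the acid is present, as the step of a number 67.2 percentage points higher from compound 1 to compound 4 (beyond the scatter) shows for hydrogen in place of ethyl on an oxygen next to a carbonyl group, with the 3-chloro-4-fluorophenyl group held the same. No measurement at hand gives a reason for any of these steps.

Still open, on these data alone, is whether the high number is kept at this carbonyl carbon by a phenyl ring carrying a methoxy group or an amine, or by a saturated ring such as cyclohexyl, since only phenyl and two halogenated phenyl rings appear here. As far as these compounds go, it is equally open whether a primary amide in place of the carboxylic acid would keep the number that the acid gives with these rings.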